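Three Measured Compounds and One Expected Value

The source may report more compounds than this note shows. Statements on the series, on what has been measured and on what is new or still open speak of the compounds shown alone.

The account covers three compounds measured in a functional assay on the whole organism (strain Wistar) for inhibition, with Rattus norvegicus as the target, read by paw edema, with stated times of 30 min and 120 min, at a dose of 50 mg/kg by the oral route (a lower number here means less inhibition, a higher number more inhibition at the dose given (going by the name of the read-out)), and a fourth that has not been tested. Compound 1 `Clc1ccc(C2=NNC(c3cn(-c4ccccc4)nc3-c3ccc(Cl)c(Cl)c3)C2)cc1` gives 48.4% in this assay, compound 2 `Fc1ccc(C2=NNC(c3cn(-c4ccccc4)nc3-c3ccc(Cl)c(Cl)c3)C2)cc1` gives 46.1%, and compound 3 `O=[N+]([O-])c1ccc(N2N=C(c3ccc(F)cc3)CC2c2cn(-c3ccccc3)nc2-c2ccc(Cl)c(Cl)c2)cc1` gives 65.6%, the highest of the three. The difference between compound 2 and compound 3 is 4-nitrophenyl in place of hydrogen on an amine nitrogen in a ring, and the step of a number 19.5 percentage points higher from compound 2 to compound 3 (beyond the scatter) lies beyond the scatter. Between compound 2 and compound 1 the change is chloro in place of fluoro on an aromatic carbon, and here a number 2.3 percentage points higher from compound 2 to compound 1 (within the scatter) stays within the scatter, so no order between compound 1 and compound 2 can be read from these two numbers. Compound 4 `O=[N+]([O-])c1ccc(N2N=C(c3ccc(Cl)cc3)CC2c2cn(-c3ccccc3)nc2-c2ccc(Cl)c(Cl)c2)cc1` has not yet been measured in this assay; it differs from compound 3 by chloro in place of fluoro on an aromatic carbon, the same change as that from compound 2 to compound 1. Because the earlier step of a number 2.3 percentage points higher from compound 2 to compound 1 (within the scatter) was within the scatter, the step expected here is a number 1.4 percentage points higher from compound 3 to compound 4 (within the scatter). The estimate for compound 4 is 67%, between 56% and 78%.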

Compound 4, a percentage reported as inhibition, in the whole organism at one dose (the size of the read-out at that dose, not a potency): 69.5%
Compound 4: the middle estimate sits 2.5 percentage points below what was measured; low and high end bracket the measured number.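

In this assay the change from 4-fluorophenyl to 4-chlorophenyl gives a step of a number 3.9 percentage points higher from compound 3 to compound 4 (within the scatter) on the core that carries 4-nitrophenyl, and it stays as small there as it was on the core with hydrogen on the ring nitrogen: the same change on two cores in this assay, a number 2.3 percentage points higher (within the scatter) from compound 2 to compound 1 and a number 3.9 percentage points higher (within the scatter) from compound 3 to compound 4, 1.6 percentage points apart, within the scatter of two such steps

Placing 4-nitrophenyl on that nitrogen carries over as well, with a step of a number 21.1 percentage points higher from compound 1 to compound 4 (beyond the scatter) on the chloro-bearing core, matching the step on the fluoro-bearing core: the same change on two cores in this assay, a number 19.5 percentage points higher (beyond the scatter) from compound 2 to compound 3 and a number 21.1 percentage points higher (beyond the scatter) from compound 1 to compound 4, 1.6 percentage points apart, within the scatter of two such steps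

These two pairs show that, for these four compounds, the two changes add up without any sign that one alters the size of the other, but they give no order between fluoro and chloro and say nothing of cores outside this set.

The compounds shown leave open whether a methoxy group or a nitrile in the same place on that ring would also leave the read-out unmoved. They also leave open what an unsubstituted phenyl or an acetyl group on the ring nitrogen would give in place of 4-nitrophenyl.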